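The source may hold more compounds than are shown below. What is called first, only, known or untested is meant among the compounds shown, and "the series" means these compounds.

Measured so far:
compound 1, `Cn1cc(C2CC(c3ccccc3)=NN2C(=O)c2cccnc2)c2ccccc21`: > 10000 nM
compound 2, `COc1ccc(C(=O)N2N=C(c3ccccc3)CC2c2cn(C)c3ccccc23)cn1`: 3980 nM
compound 3, `COc1ccc(C2=NN(C(=O)c3cccnc3)C(c3cn(C)c4ccc(Br)cc34)C2)cc1OC`: 2090 nM

In a functional assay on HeLa cells (Homo sapiens) for inhibition, read by MTT assay, with a stated time of 48 h (a higher number here means a weaker inhibitor of growth, a lower number a stronger inhibitor of growth), compound 1 gives only a limit, > 10000 nM. Compound 2 gives 3980 nM, and the change between the two is methoxy in place of hydrogen on an aromatic carbon, which brings an at least 2.5-fold lower number from compound 1 to compound 2 (0.40 log units; beyond the scatter). That step rests on (the limit of > 10000 nM in this assay, at which 1 of the 3 values shown sits), the limit at which compound 1 sits, so its true size is not pinned down. Compound 3 gives 2090 nM; how its core differs from that of compound 1 is not broken down here, and its value sits within the scatter of compound 2.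

Compound 4, `COc1cc(C2=NN(C(=O)c3cccnc3)C(c3cn(C)c4ccc(Br)cc34)C2)cc(OC)c1OC`, has not yet been measured. It differs from compound 3 by methoxy in place of hydrogen on an aromatic carbon. This is the same kind of change as from compound 1 to compound 2, but not the same: there the methoxy entered a six-membered aromatic ring with 1 nitrogen, next to the ring nitrogen and para to a large group, whereas here it enters a ring of carbon only, ortho to a methoxy group, meta to a large group and meta to a methoxy group. Resting on an at least 2.5-fold lower number from compound 1 to compound 2 (0.40 log units; beyond the scatter), a step of a 2.1-fold lower number from compound 3 to compound 4 (0.32 log units; beyond the scatter) is expected. Compound 4 is estimated at 1000 nM, between 350 nM and 3000 nM.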

Compound 4, concentration for 50% growth inhibition: > 10000 nM
Compound 4 was reported as a limit; the forecaster's own chance of this, stated with the estimate: 3%; middle value at least 10-fold (1.00 log units) from the limit.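

In this assay, the change from 3,4-dimethoxyphenyl to 3,4,5-trimethoxyphenyl brought an at least 4.7-fold higher number from compound 3 to compound 4 (0.67 log units; beyond the scatter), so the methoxy-for-hydrogen change did not carry over from the core of compound 1 to the core of compound 3, and the two steps point in opposite directions: the same change on two cores in this assay, an at least 2.5-fold lower number (0.40 log units; beyond the scatter) from compound 1 to compound 2 and an at least 4.7-fold higher number (0.67 log units; beyond the scatter) from compound 3 to compound 4, at least 12-fold (1.07 log units) apart, beyond the scatter of two such steps

Compound 4, like compound 1, is reported only as a limit, so the true size of neither step is pinned down: the limit of > 10000 nM in this assay, at which 2 of the 4 values shown sit.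

The comparison does not show what lies behind the reversal, as the methoxy entered a different ring in a different place and the two cores also differ elsewhere.

The compounds shown leave open how a hydroxyl or a fluorine in place of the added methoxy would read in this assay. They also leave open whether the same change would give the same result on a core without the bromine carried by compound 3.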